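The source may report more compounds than this note shows. Statements on the series, on what has been measured and on what is new or still open speak of the compounds shown alone.

Compound 1 `Cc1ccccc1S(=O)(=O)NC(C1=CC(=O)c2c(O)ccc(O)c2C1=O)C(C)C` and compound 3 `CC(C)C(NS(=O)(=O)c1cccc(Br)c1)C1=CC(=O)c2c(O)ccc(O)c2C1=O` share one core and differ in the group on a sulfonyl sulfur whose other neighbour is the sulfonamide nitrogen. In a functional assay on HL-60 cells (Homo sapiens) for cytotoxicity, read by MTT assay (a lower number here means a stronger inhibitor, a higher number a weaker inhibitor), compound 1 gives 190 nM with 2-methylphenyl in that place, while compound 3 gives 790 nM with 3-bromophenyl there. Within the data shown here, compound 3 therefore holds the higher of the two numbers so far, which makes it the weaker inhibitor of the pair. Compound 2 `CC(C)C(NS(=O)(=O)c1ccc(Br)cc1)C1=CC(=O)c2c(O)ccc(O)c2C1=O` adds nothing to the comparison, since its entry reads "not determined" (no result reported) with no number behind it.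

Compound 4 `CC(=O)c1ccc(S(=O)(=O)NC(C2=CC(=O)c3c(O)ccc(O)c3C2=O)C(C)C)cc1` has 4-acetylphenyl in place of 3-bromophenyl on a sulfonyl sulfur and keeps the rest of the structure. Among the measured compounds shown here, one measured step bears on this change: a 4.2-fold higher number from compound 1 to compound 3 (0.62 log units; beyond the scatter) for a swap in the same place. For the measured compounds named here, that modest step shows that the number can move with this group, but it is a single step, and no measured compound carries an acetyl group. Going by the values given here, the only other number, compound 1 at 190 nM in this series, lies lower, so a slight drift downward is the more reasonable guess. The expected step is a 1.4-fold lower number from compound 3 to compound 4 (0.15 log units; within the scatter) and would not go beyond the scatter. In this assay the estimate for compound 4 is 560 nM with an expected range from 170 nM to 1800 nM at its two ends.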

Compound 4, half-maximal inhibitory concentration: 110 nM
Beside the measured number, compound 4's estimate is 5.1-fold (0.71 log units) above it, and the stated range ends above it.
By their numbers in this assay, from the lowest: compounds 4 and 1 (each within the scatter of the next); then compound 3.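

In this assay, the result shows that the group on a sulfonyl sulfur can move the number down as well as up: the earlier step rose, while this change gives a 7.2-fold lower number from compound 3 to compound 4 (0.86 log units; beyond the scatter). The other new step, a 1.7-fold lower number from compound 1 to compound 4 (0.24 log units; within the scatter), shows that 4-acetylphenyl and 2-methylphenyl cannot be told apart here, so among the three compounds with numbers, only compound 3, with its 3-bromophenyl, stands apart from the other two. Nothing available explains why these groups give such numbers, and no outside measurement bears on the difference.

Compound 2 has no number, so the compounds shown cannot say whether compound 3 stands apart for its bromine or for where that bromine sits on the ring. Also open, as far as these compounds go, is how the number would respond if the aromatic ring on the sulfonyl sulfur carried an amine or a carboxylic acid, or if a longer carbon chain took the place of that ring.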